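The source may hold more compounds than are shown below. What is called first, only, known or untested is meant among the compounds shown, and "the series" means these compounds.

Measured so far:
compound 1 `CO/N=C(\CCN1CCN(c2ccccn2)CC1)c1ccccc1Cl` — 42.3 nM
compound 2 `CO/N=C(\CCN1CCN(c2ccccn2)CC1)c1ccc(Cl)cc1` — 37.6 nM
compound 3 `CO/N=C(/CCN1CCN(c2ccccn2)CC1)c1ccc(Cl)cc1` — 56.6 nM

In a functional assay on HEK293 cells with D(4) dopamine receptor (Homo sapiens) as the target, read by FLIPR (on this read-out lower numbers stand for an effect already at smaller amounts and higher numbers for an effect only at larger amounts of compound), compound 2 gives 37.6 nM, the lowest of the three numbers, though both neighbouring steps, a 1.1-fold lower number from compound 1 to compound 2 (0.05 log units; within the scatter) and a 1.5-fold higher number from compound 2 to compound 3 (0.18 log units; within the scatter), stay within the scatter, so the three compounds are not separated. The second of these rests only on (the fact that compounds 2 and 3 differ only in the configuration as drawn).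

Compound 4 `CO/N=C(\CCN1CCN(c2ccccn2)CC1C)c1ccc(Cl)cc1` differs from compound 2 by methyl in place of hydrogen on a saturated ring carbon. Neither measured step touches the saturated ring: one moves the chlorine on the aryl group, the other changes only the drawn configuration. Both were small. Among the measured compounds shown here, no step therefore bears directly on the new change, and with nothing pointing either way, the step from compound 2 to compound 4 is expected to be a 1.2-fold higher number from compound 2 to compound 4 (0.08 log units; within the scatter). In this assay compound 4 is estimated at 45 nM, between 18 nM and 120 nM.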

Compound 4, half-maximal effective concentration: 333 nM
Compound 4: the middle estimate sits 7.4-fold (0.87 log units) below what was measured, outside the stated range (above it).
By their numbers in this assay, from the lowest: compounds 2, 1 and 3 (each within the scatter of the next); then compound 4.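

In this assay, methyl in place of hydrogen on a saturated ring carbon next to the ring nitrogen gives an 8.9-fold higher number from compound 2 to compound 4 (0.95 log units; beyond the scatter), the only step shown that lies beyond the scatter. This position therefore responds to a single added carbon, whereas moving the chlorine and changing the drawn configuration left compounds 1, 2 and 3 unseparated. Nothing available explains this step.

The compounds shown leave open whether ethyl or hydroxymethyl on this carbon gives a step of similar size. They also leave open whether methyl on another carbon of the ring does the same.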